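Lengthening the Amide Chain from Propyl to Butyl

The source may report more compounds than this note shows. Statements on the series, on what has been measured and on what is new or still open speak of the compounds shown alone.

Compound 1 `CCC1C(=O)N(C)c2cnc(-n3ccc4cc(C(=O)NC(C)C)ccc43)nc2N1c1ccn(C)n1`: 22000 nM
Compound 2 `CCC1C(=O)N(C)c2cnc(-n3ccc4cc(F)ccc43)nc2N1c1ccn(C)n1`: "not active" (no number reported)
Compound 3 `CCCNC(=O)c1ccc2c(ccn2-c2ncc3c(n2)N(c2ccn(C)n2)C(CC)C(=O)N3C)c1`: "not active" (no number reported)

All three compounds were tested in a functional assay on A549 cells (Homo sapiens) for antiproliferative activity, read by CCK-8 assay, with a stated time of 72 h (a higher number here means a weaker inhibitor of growth, a lower number a stronger inhibitor of growth), and compound 3 is recorded as "not active" (no number reported) with no single number. It shares that position with compound 2, also recorded as "not active" (no number reported) in this set. Only compound 1 has a number, 22000 nM in the same test, so compound 3 offers no numerical starting point.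

Compound 4 `CCCCNC(=O)c1ccc2c(ccn2-c2ncc3c(n2)N(c2ccn(C)n2)C(CC)C(=O)N3C)c1` has not yet been measured. The change is methyl in place of hydrogen on a saturated chain carbon, three bonds along the chain from an amide-type nitrogen and it takes the amide chain from propyl to butyl, with the methyl on a saturated chain carbon, three bonds along the chain from an amide-type nitrogen. Within the data shown here, no two measured compounds differ in one place only, so the data give no step size to carry over. No shift beyond the scatter is expected in either direction, and compound 4 is expected to remain a weak inhibitor of growth, quite possibly without a number. Among the measured compounds shown here, the only numerical guide is compound 1 at 22000 nM in this series. The estimated value for compound 4 is 25000 nM with an expected range from 10000 nM to 60000 nM if a number is reported at all.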

Compound 4, concentration for 50% growth inhibition: 37300 nM
Compound 4: the middle estimate sits 1.5-fold (0.17 log units) below what was measured, and the stated range covers the measured number.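

In this assay compound 4, with the butyl chain, gives 37300 nM, so this amide position now holds a number where compound 3, with the propyl chain, holds none, and the step for methyl in place of hydrogen on a saturated chain carbon, three bonds along the chain from an amide-type nitrogen, cannot be read. Among these compounds, the one change that can be read at this position is butyl in place of isopropyl on the amide-type nitrogen, which gives a 1.7-fold higher number from compound 1 to compound 4 (0.23 log units; within the scatter), so this test does not tell these two chains apart. Nothing given here accounts for the result or for the lack of a number for compound 3.

On these data alone, whether a longer chain, or a chain carrying an amine or a carboxylic acid, would give a clearly lower number remains open. Also open, as far as these compounds go, is how far compound 3 really stands from compound 4, since an entry without a number gives no size to compare.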